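The source may hold more compounds than are shown below. What is called first, only, known or untested is meant among the compounds shown, and "the series" means these compounds.

Compound 1, `COC(=O)C1=CO[C@@H](O[C@@H]2O[C@H](CO)[C@@H](O)[C@H](O)[C@H]2O)[C@@H]2[C@@H](COC(=O)/C=C/c3ccc(O)cc3)CC[C@H]12`, is an iridoid glycoside carrying a cinnamate ester whose double bond is drawn E. In a functional assay on HeLa S3 cells (Homo sapiens) for cytotoxicity, read by WST assay (a higher number here means a weaker inhibitor, a lower number a stronger inhibitor), compound 1 gives 100000 nM, the highest number among the three measured compounds, so it is the weakest of the three on this read-out. The other two measured compounds are built on a different core: compound 2, `CC(C)CC(=O)O[C@@H]1OC=C(CO)[C@H]2C[C@H](OC(=O)/C=C\c3ccc(O)cc3)[C@](O)(CO)[C@@H]12`, gives 3110 nM in this assay, and compound 3, `CCC(C)CC(=O)O[C@@H]1OC=C(CO)[C@H]2C[C@H](OC(=O)/C=C/c3ccc(O)cc3)[C@](O)(CO)[C@@H]12`, gives 7400 nM. Both of these numbers lie well below that of compound 1, beyond the usual scatter, and compound 2 with its Z-drawn ester sits lower than compound 3 with its E-drawn ester, although these two compounds differ in more than one place, so nothing can be attributed to the double bond alone from that pair.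

Compound 4, `COC(=O)C1=CO[C@@H](O[C@@H]2O[C@H](CO)[C@@H](O)[C@H](O)[C@H]2O)[C@@H]2[C@@H](COC(=O)/C=C\c3ccc(O)cc3)CC[C@H]12`, is the counterpart of compound 1 in which only the drawing of the double bond changes: the two compounds have the same atoms and bonds and differ only in configuration as drawn: 1 of 10 stereo elements differ; a double bond is drawn E in compound 1 and Z in compound 4. For the measured compounds named here, no step between two measured compounds isolates this change. Compound 1 already lies at a very high number, and a single change in configuration is expected to move the result little, if at all. The step of a 1.4-fold lower number from compound 1 to compound 4 (0.15 log units; within the scatter) is therefore expected to stay within the scatter or to be small, and compound 4 is estimated at 70000 nM, somewhere between 25000 nM and 150000 nM.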

Compound 4, half-maximal inhibitory concentration: 100000 nM
Estimate against measurement, compound 4: 1.4-fold (0.15 log units) below; measured number inside the range.
By their numbers in this assay, from the lowest: compound 2; then compound 3; then compounds 1 and 4 (each within the scatter of the next).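

For the compounds shown here, the pair gives the first comparison in this set that isolates a single feature: the fact that compounds 1 and 4 differ only in the configuration as drawn. In this assay, turning the double bond of the cinnamate ester from the E to the Z drawing gives no change at the digits printed from compound 1 to compound 4 (within the scatter), so on this core the drawing of that bond does not separate the two compounds. The earlier compounds shown here could not show this, since compound 2 and compound 3 differ in more than one place and their E and Z esters could not be read apart.

The compounds shown leave open whether the same holds on the core of compound 2 and compound 3, where the numbers are much lower and a difference tied to the double bond would have more room to appear. They also leave open what this assay would give with a methoxy group in place of the phenol hydroxyl of the cinnamate, or with an amide in place of its ester.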